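The source may report more compounds than this note shows. Statements on the series, on what has been measured and on what is new or still open speak of the compounds shown alone.

Of the compounds shown here, three built on one shared core have been measured in a functional assay on NUGC-3 cells (Homo sapiens) for cytotoxicity, read by sulforhodamine B assay, with a stated time of 72 h; a higher number here means a weaker inhibitor of growth, a lower number a stronger inhibitor of growth. Compound 1 `O=C(Nc1ccc(C(F)(F)F)cc1)C1CCc2ccccc2N1` gives 18600 nM. Compound 3 `O=C(Nc1ccccc1C(F)(F)F)C1CCc2ccccc2N1` gives 39300 nM, the highest of the two numbers, with compound 1 standing lower. Compound 2 `CCCC(=O)N1c2ccccc2CCC1C(=O)Nc1ccccc1C(F)(F)F` carries a propylcarbonyl on a nitrogen on an aromatic ring in a ring; in this assay compound 2 reaches only > 70000 nM, which is a limit and not a number. Among the measured compounds shown here, the one measured step that bears here is an at least 1.7-fold lower number from compound 2 to compound 3 (0.25 log units; that floor lies within the scatter), a step whose floor comes from the limit of > 70000 nM in this assay, at which 1 of the 3 values shown sits. Compound 4 `O=C(Nc1ccccc1C(F)(F)F)C1CCc2ccccc2N1C(=O)c1ccccc1` differs from compound 3 by benzoyl in place of hydrogen on a nitrogen on an aromatic ring in a ring. This runs in the opposite direction to that step, with an acyl group again entering on a nitrogen on an aromatic ring in a ring, so a higher number is expected for compound 4 in this assay, quite possibly at the limit once more. The expected step is a 1.8-fold higher number from compound 3 to compound 4 (0.25 log units; within the scatter). Compound 4 is estimated at 70000 nM, within a range from 30000 nM to 200000 nM.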

Compound 4, concentration for 50% growth inhibition: 8120 nM
Compound 4: middle estimate off by 8.6-fold (0.94 log units), on the high side; measured number below the stated range.
By their numbers in this assay, from the lowest: compound 4; then compound 1; then compound 3. At a limit, above all of these: compound 2.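

Placing an acyl group on this nitrogen does not have to weaken growth inhibition in this assay: benzoyl in place of hydrogen gives a 4.8-fold lower number from compound 3 to compound 4 (0.68 log units; beyond the scatter). The outcome depends on what the carbonyl carries, since phenyl in place of propyl gives an at least 8.6-fold lower number from compound 2 to compound 4 (0.93 log units; beyond the scatter), so compound 4 gains on compound 3 whereas compound 2, with its propylcarbonyl, shows no such gain. The true size of that second step is unknown, as it is only a floor set by a limit and not by a number: the limit of > 70000 nM in this assay, at which 1 of the 4 values shown sits.

The compounds shown leave open whether the carbonyl itself is needed, which a benzyl group on the same nitrogen could test, and whether a methoxy group on the benzoyl ring would shift the number further. They also leave open whether benzoyl would lower the number for compound 1 as it does for compound 3.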